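Switching the triazole substituent from an amide linker to a direct aryl

This account rests on a few compounds, and the source may have more. Where it says the series, first, only, none or still open, it means among the compounds named here.

Of the compounds shown here, three sharing one core have been measured in a functional assay on HeLa cells (Homo sapiens) for inhibition, read by MTT assay, with a stated time of 24 h; on this read-out higher numbers stand for weaker inhibition and lower numbers for stronger inhibition. Compound 1 `CCOC(=O)C1=Cc2ccccc2OC1(OCc1cn(CC(=O)Nc2ccc(OC)cc2)nn1)C(F)(F)F` gives 31900 nM. Compound 2 `CCOC(=O)C1=Cc2ccccc2OC1(OCc1cn(-c2ccc(F)c([N+](=O)[O-])c2)nn1)C(F)(F)F` gives 15600 nM, and compound 3 `CCOC(=O)C1=Cc2ccccc2OC1(OCc1cn(CC(=O)Nc2ccccc2F)nn1)C(F)(F)F` gives 49900 nM. Compound 3 therefore carries the highest of the three numbers: the step of a 1.6-fold higher number from compound 1 to compound 3 (0.19 log units; within the scatter) is within the scatter, while the step of a 3.2-fold higher number from compound 2 to compound 3 (0.50 log units; beyond the scatter) is beyond it.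

The next compound, compound 4 `CCOC(=O)C1=Cc2ccccc2OC1(OCc1cn(-c2ccc(F)c(Cl)c2)nn1)C(F)(F)F`, is made from compound 3 by a single change: 3-chloro-4-fluorophenyl in place of ((2-fluorophenyl)carbamoyl)methyl on an aromatic nitrogen.

Two measured steps speak to this change. The step of a 3.2-fold higher number from compound 2 to compound 3 (0.50 log units; beyond the scatter) is its near mirror image, since there a directly attached aromatic ring on the triazole nitrogen was exchanged for a carbamoylmethyl linker carrying a ring. The step of a 2.0-fold lower number from compound 1 to compound 2 (0.31 log units; beyond the scatter) points the same way, a directly attached ring giving a lower number than a linker-borne one. Both steps are modest, and the ring entering compound 4 differs from that of compound 2 only in one group, so a step of similar size is expected: a 3.1-fold lower number from compound 3 to compound 4 (0.49 log units; beyond the scatter). On that basis compound 4 is estimated at 16000 nM, with a likely range from 6000 nM to 45000 nM.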

Compound 4, half-maximal inhibitory concentration: 22700 nM
For compound 4 the middle estimate is 1.4-fold (0.15 log units) below the measured one, within the range that was stated.
By their numbers in this assay, from the lowest: compounds 2, 4, 1 and 3 (each within the scatter of the next, the first and the last beyond it).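

In this assay, the step of a 2.2-fold lower number from compound 3 to compound 4 (0.34 log units; beyond the scatter) shows that a directly attached ring can give a lower number than a linker-borne one with a second ring on this aromatic nitrogen, not only with the 4-fluoro-3-nitrophenyl group. The step for chloro in place of nitro on the ring (a 1.5-fold higher number from compound 2 to compound 4 (0.16 log units; within the scatter)) lies within the scatter, so these two compounds cannot be told apart and the nitro group is not needed to reach this level. The pattern does not hold throughout, since the step of a 1.4-fold lower number from compound 1 to compound 4 (0.15 log units; within the scatter) also lies within the scatter, leaving the direct ring not clearly different from the linker carrying 4-methoxyphenyl. Nothing available explains why the direct ring gives a clear step from one linker-borne compound and no clear step from the other.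

The compounds shown leave open whether plain phenyl, with no halogen on the ring, would give a similar number on this nitrogen. They also leave open what a benzyl group, with a single carbon between the nitrogen and the ring, or a directly attached ring carrying an amine or a carboxylic acid would do.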